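The source may hold more compounds than are shown below. What is called first, only, known or untested is meant among the compounds shown, and "the series" means these compounds.

Compound 1 `O=c1cc(-c2ccccc2)oc2cc(OCCCCNc3nc4ccc(Cl)cc4s3)cc(O)c12`: 13.2 ug/mL in a physicochemical assay, read by spectrophotometry, with a stated time of 25 min; a lower number here means a stronger inhibitor, a higher number a weaker inhibitor
Compound 2 `O=c1cc(-c2ccccc2)oc2cc(OCCCCNc3nc4ccc(I)cc4s3)cc(O)c12`: 25.4 ug/mL in this assay

Compound 2 stands at one end of these two numbers, but the step of a 1.9-fold higher number from compound 1 to compound 2 (0.28 log units; within the scatter) lies within the scatter, so the two compounds cannot be told apart on this evidence. Compound 3 `O=c1cc(-c2ccccc2)oc2cc(OCCCCNc3nc4ccc(F)cc4s3)cc(O)c12` differs from compound 2 by fluoro in place of iodo on an aromatic carbon. Within the data shown here, only one measured step bears on a halogen swap at this place, a 1.9-fold higher number from compound 1 to compound 2 (0.28 log units; within the scatter), and it is within the scatter. A further halogen swap is therefore expected to move the number little, so compound 3 is expected to show a 1.6-fold lower number from compound 2 to compound 3 (0.20 log units; within the scatter). The estimate for compound 3 is 16 ug/mL, within a range from 7 ug/mL to 35 ug/mL.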

Compound 3, half-maximal inhibitory concentration: 14.7 ug/mL
Compound 3: middle estimate off by 1.1-fold (0.04 log units), on the high side; the range from low to high includes it.
By their numbers in this assay, from the lowest: compounds 1, 3 and 2 (each within the scatter of the next).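

Fluoro at this place gives a 1.7-fold lower number from compound 2 to compound 3 (0.24 log units; within the scatter) and a 1.1-fold higher number from compound 1 to compound 3 (0.05 log units; within the scatter) in this assay and so joins chloro and iodo with no step beyond the scatter. Where one pair of halogens stood before, three now show that swapping among these halogens on this aromatic carbon leaves compounds that cannot be told apart. No measurement at hand offers a reason for this result. Still open, from the compounds shown here alone, is whether a non-halogen group here, such as an amine or a carboxylic acid, would move the number beyond the scatter. Going by these compounds, the effect of a longer linking chain also remains open.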